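Adding one fluoro to compound 1

The compounds below may be only part of what the source reports. "The series", "measured", "known", "first", "only" and "open" are said of these compounds alone.

compound 1 `COc1cc2c(Oc3ccc(NC(=O)Nc4ccccc4)cc3)ccnc2cc1OCCCCCCC(=O)NO`: 1040 nM
compound 2 `COc1cc2c(Oc3ccc(NC(=O)Nc4ccccc4C(F)(F)F)cc3)ccnc2cc1OCCCCCCC(=O)NO`: 1080 nM
compound 3 `COc1cc2c(Oc3ccc(NC(=O)Nc4ccc(C(F)(F)F)cc4Cl)cc3)ccnc2cc1OCCCCCCC(=O)NO`: 500 nM

These values come from a functional assay on MCF7 cells (Homo sapiens) for antiproliferative activity, read by MTT assay; on this read-out higher numbers stand for weaker inhibition and lower numbers for stronger inhibition. Compound 1 sits with compound 2 at the upper end of these numbers, the two lying within the scatter of each other, while compound 3 lies lower, beyond the scatter. Compound 4 `COc1cc2c(Oc3ccc(NC(=O)Nc4ccccc4F)cc3)ccnc2cc1OCCCCCCC(=O)NO` differs from compound 1 by a single change, (fluoro in place of hydrogen on an aromatic carbon), fluoro in place of hydrogen on an aromatic carbon. The closest measured precedent is a 1.0-fold higher number from compound 1 to compound 2 (0.02 log units; within the scatter), where trifluoromethyl replaces hydrogen. The other step, a 2.1-fold lower number from compound 1 to compound 3 (0.32 log units; beyond the scatter), is a larger replacement and only modest. No step beyond the scatter is therefore expected in this assay. The expected step is a 1.1-fold lower number from compound 1 to compound 4 (0.04 log units; within the scatter). For compound 4 the estimate is 950 nM, within an expected range of 450 nM to 2000 nM.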

Compound 4, half-maximal inhibitory concentration: 660 nM
Compound 4: middle estimate off by 1.4-fold (0.16 log units), on the high side, and the stated range covers the measured number.
By their numbers in this assay, from the lowest: compounds 3, 4, 1 and 2 (each within the scatter of the next, the first and the last beyond it).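

In this assay, fluoro on this aromatic carbon, ortho to a large group, gives a step within the scatter (a 1.6-fold lower number from compound 1 to compound 4 (0.20 log units; within the scatter)). Fluoro in place of trifluoromethyl is also within the scatter (a 1.6-fold lower number from compound 2 to compound 4 (0.21 log units; within the scatter)), as is the exchange with the ring of compound 3 (a 1.3-fold higher number from compound 3 to compound 4 (0.12 log units; within the scatter)), so compound 4 cannot be separated from any of the other three compounds, even though compound 1 and compound 3 lie apart. Nothing available accounts for these numbers. From the compounds shown here alone, whether an amine or a nitrile at this place would give a step beyond the scatter remains open.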